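This account rests on a few compounds, and the source may have more. Where it says the series, first, only, none or still open, it means among the compounds named here.

Among the measured compounds shown here, in a functional assay on A549 cells (Homo sapiens) for cytotoxicity, read by MTT assay, with a stated time of 72 h (on this read-out lower numbers stand for stronger inhibition and higher numbers for weaker inhibition), compound 3 `COc1ccc(/C=C2\CCC/C(=C\c3ccc(Br)cc3)C2=O)cc1OC` gives 16000 nM, the only true number among the three compounds measured so far. Compound 1 `COc1cccc(/C=C2\CCC/C(=C\c3ccc(Cl)cc3)C2=O)c1OC` reads > 20000 nM, which is a limit of the assay and not a number. Compound 2 `COc1cccc(/C=C2\CCC/C(=C\c3cccc(O)c3)C2=O)c1OC` reads > 20000 nM, again a limit only.

Compound 4 `COc1ccc(/C=C2\CCC/C(=C\c3ccc(Cl)c(Cl)c3)C2=O)cc1OC` keeps the core of compound 3 and changes one group: 3,4-dichlorophenyl in place of 4-bromophenyl on a double-bonded chain carbon bound to a double-bonded ring carbon. The new group, 3,4-dichlorophenyl, sits in the same place, on a double-bonded chain carbon bound to a double-bonded ring carbon, and it keeps a halogen-bearing phenyl ring there.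

For the measured compounds named here, the one measured step between close neighbours is a step that the two limits leave unreadable from compound 1 to compound 2, so it offers no size to carry over. The other guide is the limit of > 20000 nM in this assay, at which 2 of the 3 values shown sit, and a reading for compound 4 could end at that limit too. With so little to go on, the expected change is a 1.1-fold lower number from compound 3 to compound 4 (0.06 log units; within the scatter), with no direction expected beyond the scatter. For compound 4 the estimated value in this assay is 14000 nM, with an expected range from 6000 nM to 20000 nM.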

Compound 4, half-maximal inhibitory concentration: 6900 nM
For compound 4 the middle estimate is 2.0-fold (0.31 log units) above the measured one, and the stated range covers the measured number.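

In this assay, among the compounds shown here, the change to 3,4-dichlorophenyl gives a 2.3-fold lower number from compound 3 to compound 4 (0.37 log units; beyond the scatter), the first step here with a readable size, as the earlier step runs between two limits and cannot be read. The step is modest but beyond the usual scatter, so the group on a double-bonded chain carbon bound to a double-bonded ring carbon can shift this reading. Both groups are halogen-bearing phenyl rings with no hydrogen-bond donors or acceptors and no net charge, so the shift appears without any change in those counts.

On these data alone, a single step cannot separate having chlorine instead of bromine from having a second halogen, and how an amine or a carboxylic acid on this phenyl ring would read stays open. Much of the set also remains unquantified, as its limits are not numbers: the limit of > 20000 nM in this assay, at which 2 of the 4 values shown sit.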